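This account rests on a few compounds, and the source may have more. Where it says the series, first, only, none or still open, it means among the compounds named here.

Measured in a functional assay on KB cells (Homo sapiens) for cytotoxicity, read by MTT assay, with a stated time of 72 h; a lower number here means that less compound is needed, a higher number that more compound is needed for the effect:

- Compound 1 `O=C1/C(=C\c2cc3ccccc3nc2Cl)c2ccccc2N1c1c(Cl)cccc1Cl`: 10 ug/mL
- Compound 2 `O=C1/C(=C\c2ccc(F)cc2)c2ccccc2N1c1c(Cl)cccc1Cl`: 5 ug/mL
- Compound 3 `Cc1ccc2nc(Cl)c(/C=C3\C(=O)N(c4c(Cl)cccc4Cl)c4ccccc43)cc2c1`: 100 ug/mL

Compound 2, at 5 ug/mL, lies within the usual scatter of compound 1, at 10 ug/mL, and compound 3, at 100 ug/mL, lies far higher than both.

The change now in view leads to compound 4 `O=C1/C(=C\c2ccccc2[N+](=O)[O-])c2ccccc2N1c1c(Cl)cccc1Cl`. It is 2-nitrophenyl in place of 4-fluorophenyl on a double-bonded chain carbon bound to a double-bonded ring carbon.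

Going by the values given here, the only measured single-place step is a 10-fold higher number from compound 1 to compound 3 (1.00 log units; beyond the scatter). It involves a different group in a different place, so it does not predict this swap. Among the compounds with values here, it shows only that a small change in this set can move the number well beyond the scatter. Closer evidence comes from the groups on that same chain carbon, which differ between compound 1 and compound 2, yet compound 1 at 10 ug/mL and compound 2 at 5 ug/mL stay within the scatter of each other. Within the data shown here, no measured compound carries a nitro group, so the direction remains uncertain.

The expected step is a 2.0-fold higher number from compound 2 to compound 4 (0.30 log units; within the scatter), and it is not expected to exceed the scatter. For compound 4 the estimate is 10 ug/mL, with an expected range from 3 ug/mL to 40 ug/mL.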

Compound 4, concentration for half-maximal effect: 1 ug/mL
For compound 4 the middle estimate is 10-fold (1.00 log units) above the measured one; the whole stated range lies above it.
By their numbers in this assay, from the lowest: compound 4; then compounds 2 and 1 (each within the scatter of the next); then compound 3.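

In this assay, the replacement of 4-fluorophenyl by 2-nitrophenyl on a double-bonded chain carbon bound to a double-bonded ring carbon gives a 5.0-fold lower number from compound 2 to compound 4 (0.70 log units; beyond the scatter). Going by these compounds alone, the earlier groups at this place had stayed within the scatter of each other, so this is the first sign that a change here can move the number beyond the scatter, and the move is towards less compound being needed, with compound 4 at 1 ug/mL now first in the order of the set. The entering group differs from the leaving one in its count of hydrogen-bond acceptors and of heavy atoms, but no measurement here ties the step to either difference or offers any explanation for it.

The compounds shown leave open whether the step belongs to the nitro group itself, since what an amine or a carboxylic acid on the same phenyl ring would give remains unknown. From the compounds shown here alone, it also remains open whether a methyl group on the shared core would repeat on compound 4 what was seen as a 10-fold higher number from compound 1 to compound 3 (1.00 log units; beyond the scatter).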